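The compounds below may be only part of what the source reports. "The series", "measured", "known", "first", "only" and "open" are said of these compounds alone.

Compound 2 `COc1ccc(NC(=O)Nc2nc(Sc3c[nH]c4ccccc34)cc(N3CCCCC3)n2)cc1`: 13500 nM
Compound 1 `Cc1cc(Cl)ccc1NC(=O)Nc1nc(Sc2c[nH]c3ccccc23)cc(N2CCN(Cc3ccccc3)CC2)n1`: > 50000 nM (a limit)
Compound 3 `COc1ccc(NC(=O)Nc2nc(Sc3c[nH]c4ccccc34)cc(N3CCN(c4ccccn4)CC3)n2)cc1`: > 50000 nM (a limit)

Going by the values given here, compound 2 holds the only number in the set: in a functional assay on A549 cells (Homo sapiens) for inhibition, with a stated time of 72 h (on this read-out lower numbers stand for stronger inhibition and higher numbers for weaker inhibition), compound 2 gives 13500 nM. For compound 1 the assay reports only a limit, > 50000 nM. For compound 3 the assay likewise reports only a limit, > 50000 nM, and the limit of > 50000 nM in this assay, at which 2 of the 3 values shown sit, is where two of the three values sit. Among the compounds with values here, the one measured step, an at least 3.7-fold higher number from compound 2 to compound 3 (0.56 log units; beyond the scatter), concerns the group on an aromatic carbon and not the urea end. Compound 4 `Cc1ccc(C)c(NC(=O)Nc2nc(Sc3c[nH]c4ccccc34)cc(N3CCCCC3)n2)c1` differs from compound 2 in 2,5-dimethylphenyl in place of 4-methoxyphenyl on an amide-type nitrogen. Within the data shown here, no measured step touches this end, so the direction is open and compound 4 is expected to lie near 20000 nM, within 6000 nM to 60000 nM. That expectation corresponds to a 1.5-fold higher number from compound 2 to compound 4 (0.17 log units; within the scatter).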

Compound 4, half-maximal inhibitory concentration: 25400 nM
For compound 4 the middle estimate is 1.3-fold (0.10 log units) below the measured one; the measured number falls inside the stated range.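

The step at the amide-type nitrogen, the only one shown at this end of the molecule, reads in this assay as a 1.9-fold higher number from compound 2 to compound 4 (0.27 log units; within the scatter). Exchanging 4-methoxyphenyl for 2,5-dimethylphenyl therefore leaves the two compounds indistinguishable in this assay, whereas the earlier step concerned only the group on an aromatic carbon. Nothing given here bears on this result.

From the compounds shown here alone, it remains open whether the exchange would read the same with 4-(pyridin-2-yl)piperazin-1-yl on the aromatic carbon. Also open, going by these compounds, is how a phenyl ring carrying an amine or a carboxylic acid, or a longer alkyl chain, would behave on this nitrogen.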